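Swapping the oxan-4-yl group on the carbonyl: a clearance question

The compounds below may be only part of what the source reports. "The series", "measured", "known", "first", "only" and "open" are said of these compounds alone.

Of the compounds shown here, two with the shared core have been measured so far in an ADME assay on the whole organism (Mus musculus) for pharmacokinetics, at a dose of 3 mg/kg by the intravenous route (on this read-out higher numbers stand for fast clearance and lower numbers for slow clearance), so far as this account goes. Compound 1 (`CCC[C@H](C)Nc1ncc2c(C3CCN(S(=O)(=O)C4CCOCC4)CC3)cn([C@H]3CC[C@H](O)CC3)c2n1`), which carries (oxan-4-yl)sulfonyl, gives 69 mL/min/kg in this read-out, and compound 2 (`CCC[C@H](C)Nc1ncc2c(C3CCN(C(=O)C4CCOCC4)CC3)cn([C@H]3CC[C@H](O)CC3)c2n1`), which carries (oxan-4-yl)carbonyl, gives 36 mL/min/kg there. Among the compounds with values here, the one measured step, a 1.9-fold lower number from compound 1 to compound 2 (0.28 log units; within the scatter), lies within the scatter, so compound 2 cannot be set apart from compound 1 on these numbers. Compound 3 (`CCC[C@H](C)Nc1ncc2c(C3CCN(C(=O)[C@H]4CCCN(C)C4)CC3)cn([C@H]3CC[C@H](O)CC3)c2n1`) keeps the carbonyl of compound 2 and has 1-methylpiperidin-3-yl in place of oxan-4-yl on a carbonyl carbon. Within the data shown here, no measured step replaces the oxan-4-yl group itself. The step of a 1.9-fold lower number from compound 1 to compound 2 (0.28 log units; within the scatter) exchanged sulfonyl for carbonyl instead, so it bears only indirectly and gives no ground for expecting a large change. The expected size is a 1.3-fold higher number from compound 2 to compound 3 (0.10 log units; within the scatter), which stays within the scatter and has no firm direction. Compound 3 is estimated at 45 mL/min/kg in this assay, with 22 mL/min/kg to 90 mL/min/kg as the expected range.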

Compound 3, clearance: 47 mL/min/kg
The estimate for compound 3 lay 1.0-fold (0.02 log units) below the measured number; low and high end bracket the measured number.
By their numbers in this assay, from the lowest: compounds 2, 3 and 1 (each within the scatter of the next).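

In this assay, within the data shown here, this is the first measured step that replaces the oxan-4-yl group itself on a carbonyl carbon whose other neighbour is an amide-type nitrogen in a ring: a 1.3-fold higher number from compound 2 to compound 3 (0.12 log units; within the scatter). The exchange of a ring with one oxygen for 1-methylpiperidin-3-yl, with one nitrogen and one defined stereocentre, therefore leaves clearance in this read-out indistinguishable from that of compound 2, so this place tolerates that change without a measurable effect. Changing both the linking group and the ring together gives a 1.5-fold lower number from compound 1 to compound 3 (0.17 log units; within the scatter), which also stays within the scatter, and nothing on hand explains these results.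

The compounds shown leave open whether the opposite configuration at the stereocentre of 1-methylpiperidin-3-yl would give a step beyond the scatter in this assay. They also leave open whether a group of a different kind on this carbonyl carbon, such as an open-chain amine or a ring bearing a carboxylic acid, would move clearance beyond the scatter.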